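Compound 2 to compound 3: chloro gives way to trifluoromethyl

The source may report more compounds than this note shows. Statements on the series, on what has been measured and on what is new or still open speak of the compounds shown alone.

Values in a functional assay on HepG2 cells (Homo sapiens) for antiproliferative activity, read by MTT assay, with a stated time of 24 h (on this read-out higher numbers stand for weaker inhibition and lower numbers for stronger inhibition), for the two measured compounds
- compound 1 `Cc1ccc(C)c(S(=O)(=O)n2c(-c3cn(-c4ccccc4)nc3-c3ccc(C(F)(F)F)cc3)nc3ccccc32)c1` gives 330 nM
- compound 2 `O=S(=O)(c1ccc(Cl)cc1)n1c(-c2cn(-c3ccccc3)nc2-c2ccc(C(F)(F)F)cc2)nc2ccccc21` gives 3930 nM

Compound 2, at 3930 nM as the higher of the two numbers, is the weaker inhibitor. Compound 3 `O=S(=O)(c1ccc(C(F)(F)F)cc1)n1c(-c2cn(-c3ccccc3)nc2-c2ccc(C(F)(F)F)cc2)nc2ccccc21` differs from it by trifluoromethyl in place of chloro on an aromatic carbon in that trifluoromethyl stands in place of chloro on an aromatic carbon. For the measured compounds named here, the one measured step that bears on this is a 12-fold higher number from compound 1 to compound 2 (1.08 log units; beyond the scatter) for 4-chlorophenyl in place of 2,5-dimethylphenyl on a sulfonyl sulfur, a large step. It exchanged a different pair of groups, so it sets no size here, and no step beyond the scatter is expected in this assay in either direction. The expected change is a 1.3-fold lower number from compound 2 to compound 3 (0.12 log units; within the scatter) and remains tentative. For compound 3 the estimated value is 3000 nM with an expected range from 800 nM to 9000 nM in this measurement.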

Compound 3, half-maximal inhibitory concentration: 1120 nM
Compound 3: the middle estimate sits 2.7-fold (0.43 log units) above what was measured; the range from low to high includes it.
By their numbers in this assay, from the lowest: compound 1; then compound 3; then compound 2.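

In this assay the substituent on the aromatic ring of the sulfonyl group matters by itself, since trifluoromethyl in place of chloro gives a 3.5-fold lower number from compound 2 to compound 3 (0.55 log units; beyond the scatter) on an otherwise unchanged structure. The 2,5-dimethylphenyl group still holds the lowest number of the three, as 4-(trifluoromethyl)phenyl in its place gives a 3.4-fold higher number from compound 1 to compound 3 (0.53 log units; beyond the scatter) in the same read-out. Nothing available explains either step. On these data alone, whether an amine or a methoxy group on that aromatic carbon would beat trifluoromethyl remains open. So does whether one methyl group alone would match the 2,5-dimethylphenyl group.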